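Replacing Carboxy with Hydroxy in a Growth Inhibitor

The source may report more compounds than this note shows. Statements on the series, on what has been measured and on what is new or still open speak of the compounds shown alone.

Of the compounds shown here, two have so far been tested in a functional assay on NUGC-3 cells (Homo sapiens) for antiproliferative activity, read by sulforhodamine B assay; a lower number here means a stronger inhibitor of growth, a higher number a weaker inhibitor of growth. Compound 1 `COc1cccc(OCCC(C)(C)C)c1C(=O)/C=C/c1ccc(O)cc1` returns > 30000 nM, which is a limit of the assay and not a number. Going by the values given here, compound 2 `CC(C)(C)CCOc1cccc(O)c1C(=O)/C=C/c1ccc(C(=O)O)cc1` gives 5440 nM, so it holds the only numerical reading available. No ranking can be built on this reading beyond the comparison with the limit of compound 1.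

The next compound, compound 3 `CC(C)(C)CCOc1cccc(O)c1C(=O)/C=C/c1ccc(O)cc1`, changes one place in compound 2 (hydroxy in place of carboxy on an aromatic carbon). Hydroxy stands in place of carboxy on an aromatic carbon, para to a large group, so that 4-carboxyphenyl becomes 4-hydroxyphenyl. Among the compounds with values here, no measured pair shows what this exchange does, which leaves the forecast loosely anchored. Its starting point is compound 2 at 5440 nM. The direction is a cautious guess drawn from the one limit seen so far, that of compound 1, (the limit of > 30000 nM in this assay, at which 1 of the 2 values shown sits). In this assay, the step of a 1.7-fold higher number from compound 2 to compound 3 (0.22 log units; within the scatter) is expected to be modest and towards weaker growth inhibition, though it may not clear the usual scatter by much. For compound 3 the estimated value is 9000 nM, with an expected range from 3000 nM to 30000 nM.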

Compound 3, concentration for 50% growth inhibition: 3300 nM
Estimate against measurement, compound 3: 2.7-fold (0.44 log units) above, and the stated range covers the measured number.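

In this assay, the exchange of carboxy for hydroxy, which turns 4-carboxyphenyl into 4-hydroxyphenyl, amounts to a 1.6-fold lower number from compound 2 to compound 3 (0.22 log units; within the scatter), so the two groups cannot be told apart at this place on the ring, even though carboxy brings more heavy atoms. The change that does register lies elsewhere in the shared core: hydrogen in place of methyl on an oxygen on an aromatic ring gives an at least 9.0-fold lower number from compound 1 to compound 3 (0.95 log units; beyond the scatter), the only step shown that clears the scatter. The reading of compound 1 in this assay is a limit of the assay and not a number, so this step has a floor but no exact size: the limit of > 30000 nM in this assay, at which 1 of the 3 values shown sits.

The compounds shown leave open whether the same exchange of methyl for hydrogen on that oxygen would count for as much with 4-carboxyphenyl in the molecule as it does with 4-hydroxyphenyl. They also leave open how an amine or a methoxy group would read in place of the hydroxy on 4-hydroxyphenyl, and whether an ethyl group on the oxygen would read like the methyl of compound 1.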